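The compounds below may be only part of what the source reports. "The series", "measured", "known", "first", "only" and "open" are said of these compounds alone.

Measured compounds:
- compound 1, `NC1=NC2(CCOCC2)N(OCCCOc2ccc(F)cc2)C(N)=N1`, "not determined" (no result reported) in an assay on isolated protein for inhibition of Dihydrofolate reductase (Homo sapiens), read by spectrophotometry, using NADPH, with stated times of 5 s and 6 min, tested at 50 uM; on this read-out higher numbers stand for a stronger effect at the one concentration tested and lower numbers for a weaker effect
- compound 2, `NC1=NC2(CCSCC2)N(OCCCOc2cc(Cl)c(Cl)cc2Cl)C(N)=N1`, 94.4%
- compound 3, `NC1=NC2(CCSCC2)N(OCCCOc2ccccc2Br)C(N)=N1`, 89.6%

Compound 1 stands without a number: in this assay it was not measured, so there is no starting value for it. The unmeasured compound 4, `NC1=NC2(CCOCC2)N(OCCCOc2cccc(Cl)c2)C(N)=N1`, differs from compound 1 in one place: 3-chlorophenyl in place of 4-fluorophenyl on an oxygen on a saturated carbon.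

Going by the values given here, only one measured step bears on this kind of change, an exchange of one halogen-bearing phenyl for another on the same oxygen. That step is a number 4.8 percentage points lower from compound 2 to compound 3 (within the scatter), and it lies within the scatter, so that exchange made no visible difference. Compounds 2 and 3 carry a core that is not the core of compound 1 and compound 4, so the carry-over is indirect. Both compounds 2 and 3 sit high in this assay, and the phenyl exchange did not move them.

Compound 4 is therefore expected to fall in a similar high region, with an estimate of 85% and a range from 60% to 98%.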

Compound 4, a percentage reported as inhibition, at one concentration (the size of the read-out at that concentration, not a potency): 85.8%
Estimate against measurement, compound 4: 0.8 percentage points below; the range from low to high includes it.
By their numbers in this assay, from the lowest: compounds 4, 3 and 2 (each within the scatter of the next).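

In this assay, going by these compounds alone, compound 1 gives "not determined" (no result reported) and so no step to compound 4 can be read. On these data alone, how 3-chlorophenyl compares with 4-fluorophenyl on the shared core stays open. Nothing shown here offers an explanation for the result of compound 4.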